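The source may hold more compounds than are shown below. What is called first, only, known or untested is meant among the compounds shown, and "the series" means these compounds.

Compounds measured so far:
Compound 1, `Cc1ccccc1/C=N/NC(N)=S`; in a functional assay on B16 cells (Mus musculus) for inhibition, tested at 10 uM (a lower number here means less inhibition, a higher number more inhibition at the concentration tested (going by the name of the read-out)), compound 1 gives > 100%, a limit of the assay rather than a number.
Compound 2, `CCc1ccccc1/C=N/NC(N)=S`; compound 2 gives > 100%, again a limit.
Compound 3, `NC(=S)N/N=C/c1ccccc1Cl`; compound 3 gives > 100%, also a limit.

Compound 3 therefore stands at the upper limit, alongside the other two. Compound 4 is `COc1ccccc1/C=N/NC(N)=S` and differs from compound 3 by methoxy in place of chloro on an aromatic carbon. The steps that touch this aromatic position are a step that the two limits leave unreadable from compound 1 to compound 3 and a step that the two limits leave unreadable from compound 2 to compound 3, and a step that the two limits leave unreadable from compound 1 to compound 2 is just as unreadable, because of the limit of > 100% in this assay, at which 3 of the 3 values shown sit. No size of step can be read from them, so the expectation for compound 4 is simply that it stays near the top: its value in this assay is estimated at 98%, within 80% to 100%, which means an expected step of a number at least 2 percentage points lower from compound 3 to compound 4 (that floor lies within the scatter).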

Compound 4, a percentage reported as inhibition, at one concentration (the size of the read-out at that concentration, not a potency): 52%
For compound 4 the middle estimate is 46 percentage points above the measured one; measured number outside the range, below it.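

In this assay, the group on this aromatic carbon clearly matters: methoxy in place of chloro gives a number at least 48 percentage points lower from compound 3 to compound 4 (beyond the scatter), methoxy in place of ethyl gives a number at least 48 percentage points lower from compound 2 to compound 4 (beyond the scatter), and methoxy in place of methyl gives a number at least 48 percentage points lower from compound 1 to compound 4 (beyond the scatter). The earlier compounds could not show this, as the steps among them cannot be read: the limit of > 100% in this assay, at which 3 of the 4 values shown sit. Compared with chloro, methoxy brings an oxygen and a hydrogen-bond acceptor, but these compounds cannot say whether either accounts for the fall.

From the compounds shown here alone, whether the oxygen itself matters remains open. So does how a hydroxyl, an amine or an ethoxy group would behave on this aromatic carbon.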